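Notes on the series: hydrogen in place of chloro

This account rests on a few compounds, and the source may have more. Where it says the series, first, only, none or still open, it means among the compounds named here.

Measured in a functional assay on K562 cells (Homo sapiens) for inhibition, read by fluorescence, with a stated time of 72 h; a higher number here means a weaker inhibitor of growth, a lower number a stronger inhibitor of growth:
- compound 1 `CCCCn1cnc2c(Nc3ccc(Cl)cc3)nc(N[C@H]3CC[C@H](N)CC3)nc21`: 2700 nM
- compound 2 `CCCCn1cnc2c(Nc3cccc(Cl)c3)nc(N[C@H]3CC[C@H](N)CC3)nc21`: 2000 nM

For the measured compounds named here, compound 1 at 2700 nM and compound 2 at 2000 nM lie within the scatter of each other, so compound 2 stands level with the only other measured compound. Compound 3 `CCCCn1cnc2c(Nc3ccccc3)nc(N[C@H]3CC[C@H](N)CC3)nc21` differs from compound 2 by hydrogen in place of chloro on an aromatic carbon. Going by the values given here, the one measured step bearing on this is a 1.4-fold lower number from compound 1 to compound 2 (0.13 log units; within the scatter). Among the compounds with values here, it only exchanges 4-chlorophenyl for 3-chlorophenyl, and no measured compound yet lacks the chloro. No step beyond the scatter is therefore expected in this assay. The estimated step is a 1.4-fold higher number from compound 2 to compound 3 (0.15 log units; within the scatter). Compound 3 is expected at 2800 nM, with an estimated range of 1200 nM to 6500 nM.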

Compound 3, concentration for 50% growth inhibition: 3200 nM
The estimate for compound 3 lay 1.1-fold (0.06 log units) below the measured number, within the range that was stated.
By their numbers in this assay, from the lowest: compounds 2, 1 and 3 (each within the scatter of the next).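

Hydrogen in place of chloro on the aromatic carbon gives, in this assay, a 1.6-fold higher number from compound 2 to compound 3 (0.20 log units; within the scatter), and read from the other chloro compound, a 1.2-fold higher number from compound 1 to compound 3 (0.07 log units; within the scatter). The unsubstituted phenyl therefore stands level with both chlorinated compounds, so this series does not show that the chloro is needed for growth inhibition in this assay. No measurement at hand bears on a cause.

Going by these compounds, whether methoxy, trifluoromethyl or a carboxylic acid on this ring would shift the number beyond the scatter remains open. So does the effect of any change away from this ring.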